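The source may report more compounds than this note shows. Statements on the series, on what has been measured and on what is new or still open speak of the compounds shown alone.

Compound 1, `Cc1ccc(S(=O)(=O)N(CCN=[N+]=[N-])[C@@H](C(=O)NO)C(C)C)cc1`, is a hydroxamic acid carrying an azide-bearing chain, and in an assay on isolated protein for inhibition of matrix metalloproteinase-9 (Homo sapiens), read by fluorescence, with a stated time of 30 min (a higher number here means a weaker inhibitor, a lower number a stronger inhibitor), compound 1 gives 4 nM. Compound 2, `CC(C)[C@H](C(=O)NO)N(CCN=[N+]=[N-])S(=O)(=O)c1ccc(OCCF)cc1`, keeps that frame; in this assay compound 2 gives 4 nM. The step of no change at the digits printed from compound 1 to compound 2 (within the scatter) therefore lies within the scatter, and the change behind it is 2-fluoroethoxy in place of methyl on an aromatic carbon.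

Compound 3, `Cc1ccc(S(=O)(=O)N(CCn2cc(COCCOCCOCCOCCOCCF)nn2)[C@@H](C(=O)NO)C(C)C)cc1`, carries instead a triazole linked to a long fluorinated ether chain; in this assay compound 3 gives 0.4 nM, the lowest of the three numbers, and the gap to compound 1 is beyond the scatter. The difference between the core of compound 3 and the core of compound 1 is not broken down here.

Compound 4, `CC(C)[C@H](C(=O)NO)N(CCn1cc(COCCOCCOCCOCCOCCF)nn1)S(=O)(=O)c1ccc(OCCF)cc1`, has not yet been measured. It differs from compound 3 by 2-fluoroethoxy in place of methyl on an aromatic carbon, the same change that turned compound 1 into compound 2 at the same place. Since that earlier step was no change at the digits printed from compound 1 to compound 2 (within the scatter), the step from compound 3 to compound 4 is expected to be no change at the digits printed from compound 3 to compound 4 (within the scatter), and compound 4 is estimated to give 0.4 nM, between 0.2 nM and 0.9 nM.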

Compound 4, half-maximal inhibitory concentration: 10 nM
Compound 4: the middle estimate sits 25-fold (1.40 log units) below what was measured, and the stated range ends below it.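

In this assay, putting 2-fluoroethoxy in place of methyl on an aromatic carbon gave a 25-fold higher number from compound 3 to compound 4 (1.40 log units; beyond the scatter), a clear weakening of inhibition. This change therefore does not carry over unchanged between these two cores, and its result on one core would have been a poor guide to its result on the other: the same change on two cores in this assay, no change at the digits printed (within the scatter) from compound 1 to compound 2 and a 25-fold higher number (1.40 log units; beyond the scatter) from compound 3 to compound 4, 25-fold (1.40 log units) apart, beyond the scatter of two such steps. With only these two pairs, this does not show which part of the cores makes the difference or why the two steps part ways, and it gives no general rule for other cores in the series.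

On these data alone, it remains open whether other groups at this place, such as an amine, a carboxylic acid or a longer chain, would also give different results on the two cores. As far as these compounds go, it is also open whether a shorter ether chain in place of the long fluorinated one would bring the two steps closer together.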